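Methyl in place of one ester on compound 1

The source may report more compounds than this note shows. Statements on the series, on what has been measured and on what is new or still open speak of the compounds shown alone.

Compound 1 (`COc1cc(/C=C/C(=O)/C=C(O)/C=C/c2ccc(OC(=O)C(C)(CO)CO)c(OC)c2)ccc1OC(=O)C(C)(CO)CO`) gives 3910 nM in a functional assay on HCT-116 cells (Homo sapiens) for antiproliferative activity, read by MTT assay, with a stated time of 72 h; a higher number here means a weaker inhibitor, a lower number a stronger inhibitor. In this assay, compound 2 (`CC(CO)(CO)C(=O)Oc1ccc(/C=C/C(=O)/C=C(O)/C=C/c2ccc(OC(=O)C(C)(CO)CO)cc2)cc1`) gives 4100 nM and compound 3 (`COc1ccc(/C=C/C(=O)/C=C(O)/C=C/c2ccc(OC)c(OC(=O)C(C)(CO)CO)c2)cc1OC(=O)C(C)(CO)CO`) gives 2790 nM. Compound 1 therefore stands in a close group, with all three values within the usual scatter of one another, so no order can be read among them. All three compounds carry (1,1-bis(hydroxymethyl)ethyl)carbonyl on an oxygen on an aromatic ring.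

Compound 4 (`COc1ccc(/C=C/C(O)=C/C(=O)/C=C/c2ccc(OC(=O)C(C)(CO)CO)c(OC)c2)cc1OC`) has not yet been measured. It differs from compound 1 in one place: methyl in place of (1,1-bis(hydroxymethyl)ethyl)carbonyl on an oxygen on an aromatic ring. In words, it has methyl in place of (1,1-bis(hydroxymethyl)ethyl)carbonyl on an oxygen on an aromatic ring. Among the compounds with values here, no measured pair isolates this change, so the size of the step is uncertain and the expectation rests on the close values alone. With compound 1 at 3910 nM and compound 3 at 2790 nM, no step beyond the scatter is expected in this assay, in either direction. The estimated step is a 1.1-fold lower number from compound 1 to compound 4 (0.05 log units; within the scatter), a small one. For compound 4 the expected value is 3500 nM, with an estimated range of 1500 nM to 8000 nM.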

Compound 4, half-maximal inhibitory concentration: 4770 nM
Compound 4: middle estimate off by 1.4-fold (0.13 log units), on the low side; the measured number falls inside the stated range.
By their numbers in this assay, from the lowest: compounds 3, 1, 2 and 4 (each within the scatter of the next).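

In this assay, within the data shown here, methyl in place of (1,1-bis(hydroxymethyl)ethyl)carbonyl on an oxygen on an aromatic ring gives a 1.2-fold higher number from compound 1 to compound 4 (0.09 log units; within the scatter), and this is the first measured pair that isolates the change. At this position, the read-out therefore does not separate the larger ester from methyl, and compound 4, which keeps the ester on only one side of the shared core, remains in the same close group as the compounds carrying two such esters. No measured evidence bears on why this exchange leaves the number within the scatter.

As far as these compounds go, this is a single pair at a single position, so it remains open whether the same exchange would read alike on the remaining ester of compound 4 or on the esters of compound 2 and compound 3. Also open, from the compounds shown here alone, is how this oxygen would read with a free hydroxyl, an aminoacetyl group or a longer alkyl chain in place of methyl.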